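Thiophene isomer swap on two dihydropyrimidinone esters

The source may report more compounds than this note shows. Statements on the series, on what has been measured and on what is new or still open speak of the compounds shown alone.

Measured compounds:
- compound 1 `CC1=C(C(=O)OC(C)(C)C)C(c2cccs2)NC(=O)N1C`: 22%
- compound 2 `CC1=C(C(=O)OC(C)(C)C)C(c2ccsc2)NC(=O)N1C`: 14%
- compound 3 `CCC(CC)OC(=O)C1=C(C)NC(=O)NC1c1cccs1`: 1%

In an assay on membranes from HeLa cells for displacement of a labelled ligand from adenosine receptor A3 (Homo sapiens), read by scintillation counting, with a stated time of 180 min, tested at 1 uM (on this read-out higher numbers stand for more inhibition at the one concentration tested (going by the name of the read-out) and lower numbers for less inhibition), compound 1 gives 22% and compound 2 gives 14%. The change between them is thiophen-3-yl in place of thiophen-2-yl on a saturated ring carbon and the step is a number 8 percentage points lower from compound 1 to compound 2 (within the scatter), so the two isomers sit within the usual scatter of each other. Compound 3 gives 1%, the lowest of the three numbers, beyond the scatter from both compound 2 and compound 1. The difference between the core of compound 1 and the core of compound 3 is not broken down here.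

Compound 4 `CCC(CC)OC(=O)C1=C(C)NC(=O)NC1c1ccsc1` has not yet been measured. It arises from compound 3 by thiophen-3-yl in place of thiophen-2-yl on a saturated ring carbon. This is the same kind of change as from compound 1 to compound 2, though the surroundings differ: in compound 1 the neighbouring ring atom bears a tert-butoxycarbonyl group (7 heavy atoms), in compound 3 a group of 8 heavy atoms. Resting on a number 8 percentage points lower from compound 1 to compound 2 (within the scatter), a step of about a number 1 percentage points higher from compound 3 to compound 4 (within the scatter) is expected, close to no change. Compound 4 is therefore estimated at 2%, between -8% and 12%.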

Compound 4, a percentage reported as inhibition, at one concentration (the size of the read-out at that concentration, not a potency): 6%
The estimate for compound 4 lay 4 percentage points below the measured number, within the range that was stated.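

In this assay, thiophen-3-yl in place of thiophen-2-yl on a saturated ring carbon gives a number 5 percentage points higher from compound 3 to compound 4 (within the scatter), and set beside the earlier case the change reads: the same change on two cores in this assay, a number 8 percentage points lower (within the scatter) from compound 1 to compound 2 and a number 5 percentage points higher (within the scatter) from compound 3 to compound 4, 13 percentage points apart, within the scatter of two such steps. On these two cores, then, the swap between the thiophene isomers carries over with no difference that can be told apart, and neither step can be told from no change. This does not show that the two isomers are interchangeable in general: there are only two cases, each read at one concentration, and all four numbers lie low on the read-out, which leaves untested whether the same holds on a core giving much higher inhibition.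

Still open, from the compounds shown here alone, is what a carboxylic acid or an amine in place of the ester group would do on either core. Also open, going by these compounds, is how the ester group and the ring substitution each contribute to the gap between compound 1 and compound 3, two compounds that differ in more than one place.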